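The source may hold more compounds than are shown below. What is called first, only, known or untested is meant among the compounds shown, and "the series" means these compounds.

In a functional assay on RAW264.7 cells (Mus musculus) for inhibition, read by Griess assay, with a stated time of 20 h (a higher number here means a weaker inhibitor, a lower number a stronger inhibitor), compound 2 (`O=C(c1cc(-n2cc(-c3ccccc3)nn2)ccc1O)N1CCCCC1`) reads > 20000 nM, which is a limit of the assay and not a number. Compound 3 (`CC(C)CCc1cn(-c2ccc(O)c(C(=O)N3CCCCC3)c2)nn1`) differs from it on one site, with isopentyl in place of phenyl on an aromatic carbon. Compound 1 (`CCCNC(=O)c1cc(-n2cc(CCC(C)C)nn2)ccc1O`) also carries isopentyl and reads > 20000 nM, again a limit, so no clear gain is expected from the change. For the measured compounds named here, no measured step is available, and the expected step of a number no higher from compound 2 to compound 3 (the limit leaves the size open) stays within the scatter, in neither direction. Compound 3 is estimated at 20000 nM, with an expected range of 8000 nM to 40000 nM.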

Compound 3, half-maximal inhibitory concentration: > 20000 nM
Compound 3: a limit, no number; the forecaster's own chance of this, stated with the estimate: 75%; the middle value sits exactly at the limit.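

Compound 3 reads as a limit and not a number, so the steps to it from compound 1 and compound 2 cannot be read: the limit of > 20000 nM in this assay, at which 3 of the 3 values shown sit. The compounds shown leave open whether swapping isopentyl for phenyl, or piperidin-1-yl for propylamino, changes inhibition at all.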